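A few compounds are considered here, and "the series" means these few. Any claim that something is new, unique, unknown or untested is made for them only; others in the source may bear on it.

Compound 3 `CC(C)S(=O)(=O)N1CCc2nc(C#Cc3ccccc3)sc2C1` stands at the lowest of the two numbers measured in an assay on HEK293 cells for negative allosteric modulation of metabotropic glutamate receptor 5 (Homo sapiens), read by FLIPR, with a stated time of 1 h (a higher number here means a weaker inhibitor, a lower number a stronger inhibitor), where compound 3 gives 11 nM. Its nearest neighbour is compound 1 `CCC(=O)N1CCc2nc(C#Cc3ccccc3)sc2C1`, which in this assay gives 38 nM; the step of a 3.5-fold lower number from compound 1 to compound 3 (0.54 log units; beyond the scatter) came with the exchange of the propanoyl for the isopropylsulfonyl group. Compound 2 `O=C(C1CC12CCC2)N1CCc2nc(C#Cc3ccccc3)sc2C1` reached only the limit of this assay, > 10000 nM. That limit is the one noted as the limit of > 10000 nM in this assay, at which 1 of the 3 values shown sits.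

Compound 4 `O=S(=O)(N1CCCCC1)N1CCc2nc(C#Cc3ccccc3)sc2C1` differs from compound 3 in one place: piperidin-1-yl in place of isopropyl on a sulfonyl sulfur. Within the data shown here, no measured step exchanges a group on the sulfonyl sulfur, so the expectation must rest on what was seen on the carbonyl. There, the step of an at least 260-fold higher number from compound 1 to compound 2 (2.42 log units; beyond the scatter) was large, and in the reverse sense the step of an at least 900-fold lower number from compound 2 to compound 3 (2.95 log units; beyond the scatter) was also large. The exchange in compound 4 is of a different kind from either, so a loss is expected, but a smaller one, with wide uncertainty; the step is estimated as a 5.5-fold higher number from compound 3 to compound 4 (0.74 log units; beyond the scatter). Compound 4 is thus expected to give about 60 nM in this assay, within a range from 15 nM to 400 nM.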

Compound 4, half-maximal inhibitory concentration: 780 nM
Beside the measured number, compound 4's estimate is 13-fold (1.11 log units) below it, and the stated range ends below it.
By their numbers in this assay, from the lowest: compound 3; then compound 1; then compound 4. At a limit, above all of these: compound 2.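

In this assay, the sulfonyl sulfur proves to be a place where a single exchange matters greatly: putting piperidin-1-yl in place of isopropyl gives a 71-fold higher number from compound 3 to compound 4 (1.85 log units; beyond the scatter). The earlier compounds shown here showed a large upward step only on a carbonyl carbon, so a sulfonyl group on the amine nitrogen in a ring does not by itself keep the number low. Nothing at hand accounts for this step.

The exchange brings in a ring and an amine nitrogen together, so the compounds shown do not tell which of the two goes with the step. From the compounds shown here alone, how a dimethylamino group, a cyclohexyl ring or a morpholin-4-yl ring on the sulfonyl sulfur would compare with compound 3 remains open.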